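Ethylcarbamoyl to isopropylcarbamoyl: an expectation for compound 4

This account rests on a few compounds, and the source may have more. Where it says the series, first, only, none or still open, it means among the compounds named here.

Compound 1 `CC(C)NC(=O)N1CCN(C(=S)SCc2cn(Cc3ccccc3F)nn2)CC1` was tested in a functional assay on SMMC-7721 cells (Homo sapiens) for cytotoxicity, read by MTT assay, with a stated time of 72 h (a lower number here means a stronger inhibitor, a higher number a weaker inhibitor), where compound 1 gives 7130 nM. Compound 2 `CC(C)(C)NC(=O)N1CCN(C(=S)SCc2cn(Cc3ccccc3F)nn2)CC1` reaches only a limit of the assay in this assay, > 128000 nM. The difference between them is methyl in place of hydrogen on a saturated chain carbon bound to an amide-type nitrogen and two saturated chain carbons, and it brought an at least 17-fold higher number from compound 1 to compound 2 (1.25 log units; beyond the scatter); the size of that step is bounded because of the limit of > 128000 nM in this assay, at which 2 of the 3 values shown sit. Compound 3 `CCNC(=O)N1CCN(C(=S)SCc2cn(Cc3ccc(OC)cc3)nn2)CC1` likewise stops at a limit in this assay, > 128000 nM. The difference between the cores of compound 1 and compound 3 is not broken down here. Compound 4 `COc1ccc(Cn2cc(CSC(=S)N3CCN(C(=O)NC(C)C)CC3)nn2)cc1` has not been measured; it differs from compound 3 by methyl in place of hydrogen on a saturated chain carbon bound to an amide-type nitrogen and a saturated chain carbon. This is the same kind of change as that from compound 1 to compound 2, though the place differs: there the carbon is bound to two saturated chain carbons, here to one saturated chain carbon. Since compound 3 already sits at a limit, and the earlier step to compound 2 lowered potency, the step is expected to be a step that the limit leaves unreadable from compound 3 to compound 4. Compound 4 is therefore estimated at 200000 nM, between 60000 nM and 1000000 nM.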

Compound 4, half-maximal inhibitory concentration: > 128000 nM
Compound 4 gave a limit, no number; the forecaster's own chance of this, stated with the estimate: 85%; the middle value is on the limit's open side.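

In this assay compound 4 gives > 128000 nM, which is a limit of the assay and not a number. Within the data shown here, the step from ethylcarbamoyl to isopropylcarbamoyl therefore cannot be read on this core, so the data show neither that the methyl carries over a loss of potency like an at least 17-fold higher number from compound 1 to compound 2 (1.25 log units; beyond the scatter) nor that it does not, and that step sits at a different place in any case: the limit of > 128000 nM in this assay, at which 3 of the 4 values shown sit. With isopropylcarbamoyl held in place, 4-methoxyphenyl in place of 2-fluorophenyl on a saturated chain carbon bound to an aromatic nitrogen brought an at least 17-fold higher number from compound 1 to compound 4 (1.25 log units; beyond the scatter), so the one readable new step concerns the change of core and not the methyl.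

The compounds shown leave open how ethylcarbamoyl reads together with 2-fluorophenyl, which would give the methyl change a readable starting value. They also leave open whether methylcarbamoyl, or a longer chain such as butylcarbamoyl, would give a number rather than a limit with 4-methoxyphenyl.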